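The source may hold more compounds than are shown below. What is called first, only, known or untested is meant among the compounds shown, and "the series" means these compounds.

Working notes on a small set sharing one core, varied only in the aryl group attached to an aromatic carbon of that core. Compound 1 `COc1cc(-n2cnc3ccc(-c4ccccc4Cl)cc32)cc(OC)c1OC` carries 2-chlorophenyl; compound 2 `COc1cc(-n2cnc3ccc(-c4ccc(F)cc4)cc32)cc(OC)c1OC` carries 4-fluorophenyl; compound 3 `COc1cc(-n2cnc3ccc(-c4ccc(C(C)=O)cc4)cc32)cc(OC)c1OC` carries 4-acetylphenyl.

In a functional assay on MCF7 cells (Homo sapiens) for antiproliferative activity, read by MTT assay, with a stated time of 72 h (a higher number here means a weaker inhibitor, a lower number a stronger inhibitor), compound 1 gives only a limit of the assay, > 10000 nM, so its place on the numbers is a bound rather than a value (the limit of > 10000 nM in this assay, at which 1 of the 3 values shown sits). In this assay compound 2 gives 1770 nM, and compound 3 gives 1540 nM. Both departures from compound 1 move off the limit: an at least 5.6-fold lower number from compound 1 to compound 2 (0.75 log units; beyond the scatter) and an at least 6.4-fold lower number from compound 1 to compound 3 (0.81 log units; beyond the scatter). Between the two measured analogues there is a 1.1-fold lower number from compound 2 to compound 3 (0.06 log units; within the scatter), which is within the scatter.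

Compound 4 `COc1cc(-n2cnc3ccc(-c4cccc(Cl)c4)cc32)cc(OC)c1OC` is the next case; the change from compound 1 is 3-chlorophenyl in place of 2-chlorophenyl on an aromatic carbon. The two steps that bear on it both start from compound 1 and both replace 2-chlorophenyl, each by at least a modest amount in the lowering direction. Within the data shown here, no measured pair tests 3-chlorophenyl directly, so the expectation is a lowering step, probably smaller than those to compound 2 and compound 3, with a real chance of staying at the limit. Compound 4 is expected near 4000 nM, within 1200 nM to 15000 nM. For compound 4 the expected step is an at least 2.5-fold lower number from compound 1 to compound 4 (0.39 log units; beyond the scatter).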

Compound 4, half-maximal inhibitory concentration: 3120 nM
Beside the measured number, compound 4's estimate is 1.3-fold (0.11 log units) above it; measured number inside the range.
By their numbers in this assay, from the lowest: compounds 3, 2 and 4 (each within the scatter of the next, the first and the last beyond it). At a limit, above all of these: compound 1.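

Compound 4 has the same atoms as compound 1, joined differently, so the change to 3-chlorophenyl isolates where the chlorine sits on the aryl group, with no change of substituent, and that alone gives a step off the limit (an at least 3.2-fold lower number from compound 1 to compound 4 (0.50 log units; beyond the scatter)). The earlier steps shown here from compound 1 changed the substituent as well as its place, so they could not separate the two. Compared with the other measured analogues, 3-chlorophenyl cannot be told apart from 4-fluorophenyl (a 1.8-fold higher number from compound 2 to compound 4 (0.25 log units; within the scatter)) but falls short of 4-acetylphenyl by a modest step (a 2.0-fold higher number from compound 3 to compound 4 (0.31 log units; beyond the scatter)), and the size of the step from compound 1 stays open-ended because that compound's value is a limit, not a number: the limit of > 10000 nM in this assay, at which 1 of the 4 values shown sits.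

Still open, on these data alone, is whether 4-chlorophenyl would complete the chlorine series with a value near those of compound 2 and compound 3, which would separate the place of the chlorine from the identity of the substituent. Also open, as far as these compounds go, is whether an amine or a carboxylic acid on the same aryl ring would move the number further than the acetyl group of compound 3 does.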